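Tetrazolyl quinolinone series: removing one methoxy group

This account rests on a few compounds, and the source may have more. Where it says the series, first, only, none or still open, it means among the compounds named here.

Measured so far:
- compound 1, `O=c1c(-c2nn[nH]n2)c[nH]c2c(F)cccc12`: 0.625 mg/kg
- compound 2, `COc1ccc(OC)c2c(=O)c(-c3nn[nH]n3)c[nH]c12`: 1.25 mg/kg

In a functional assay on the whole organism (strain Sprague-Dawley) for inhibition, with Rattus norvegicus as the target (a lower number here means that less compound is needed, a higher number that more compound is needed for the effect), compound 1 gives 0.625 mg/kg and compound 2 gives 1.25 mg/kg. Of the two numbers, that of compound 2 is the higher, but the gap to compound 1 lies within the usual scatter of repeated measurements, so the two compounds cannot be separated on these data. Among the measured compounds shown here, nothing more is known about how substitution on the carbocyclic ring of the shared core moves this assay; no step between measured compounds exists that isolates a single change.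

Compound 3, `COc1cccc2c(=O)c(-c3nn[nH]n3)c[nH]c12`, is not yet measured in this assay. It differs from compound 2 in one place: hydrogen in place of methoxy on an aromatic carbon. One of the two methoxy groups of compound 2 is gone, the other stays.

For the measured compounds named here, with no isolated step to lean on, the expectation for compound 3 is a small step from compound 2, a 1.4-fold lower number from compound 2 to compound 3 (0.14 log units; within the scatter), not beyond the scatter, with a slight lean toward a lower number since compound 1 sits at 0.625 mg/kg with no methoxy group at all. For compound 3 the estimated minimum effective dose is 0.9 mg/kg, with a range from 0.4 mg/kg to 2.5 mg/kg.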

Compound 3, minimum effective dose: 0.15 mg/kg
Estimate against measurement, compound 3: 6.0-fold (0.78 log units) above, and the stated range ends above it.
By their numbers in this assay, from the lowest: compound 3; then compounds 1 and 2 (each within the scatter of the next).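

Hydrogen in place of methoxy gives an 8.3-fold lower number from compound 2 to compound 3 (0.92 log units; beyond the scatter) in this assay and is the first single change in the series that stands beyond the scatter. The aromatic carbon para to a methoxy group is therefore a place where this read-out responds to what is attached, and of the two groups tried there, hydrogen gives the lower dose. Methoxy in place of fluoro gives a 4.2-fold lower number from compound 1 to compound 3 (0.62 log units; beyond the scatter) in this assay and shows that one methoxy group on the shared core is compatible with the lowest number of the three, so the cost seen in compound 2 is tied to the second methoxy group and not to methoxy as such. No supporting data speak to why either step has the size it has.

Still open, from the compounds shown here alone, is whether the remaining methoxy group contributes on its own, or whether a hydroxyl group, an ethoxy group or an amine on that carbon would lower the dose further. The compounds shown also leave open whether these steps would hold if a carboxylic acid took the place of the tetrazolyl group.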